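The source may hold more compounds than are shown below. What is called first, only, known or untested is meant among the compounds shown, and "the series" means these compounds.

Measured compounds:
compound 1, `CCCCNC(=O)C1CCN(c2nc(N)c3cc(OC)c(OC)cc3n2)CC1`: 0.67 nM
compound 2, `CCN(CC)C(=O)C1CCCN(c2nc(N)c3cc(OC)c(OC)cc3n2)C1`: 117 nM

In an assay on isolated protein for displacement of a labelled ligand from Adrenergic receptor alpha-1 (Rattus norvegicus) (a lower number here means a stronger inhibitor, a higher number a weaker inhibitor), compound 1 gives 0.67 nM, the lowest of the two numbers recorded. For the measured compounds named here, compound 2 gives 117 nM in this assay, a much higher number, and the gap between the two lies beyond the scatter; no step linking the two compounds in one place has been computed, so only the two values themselves can be compared.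

Compound 3, `COc1cc2nc(N3CCC(C(=O)Nc4ccccc4)CC3)nc(N)c2cc1OC`, has not yet been measured in this assay. It differs from compound 1 in one place: phenyl in place of butyl on an amide-type nitrogen. Going by the values given here, no measured pair shows this change, so the size of the step cannot be read from the data. The author expects compound 3 to stay close to compound 1, with a step from compound 1 to compound 3 in this assay of a 1.5-fold higher number from compound 1 to compound 3 (0.17 log units; within the scatter), which amounts to no change beyond the scatter. For compound 3 the estimated value in this assay is therefore 1 nM, with a range from 0.3 nM to 4 nM.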

Compound 3, inhibition constant: 0.47 nM
Compound 3: the middle estimate sits 2.1-fold (0.33 log units) above what was measured, within the range that was stated.
By their numbers in this assay, from the lowest: compounds 3 and 1 (each within the scatter of the next); then compound 2.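

In this assay, phenyl in place of butyl on the amide-type nitrogen gives a 1.4-fold lower number from compound 1 to compound 3 (0.15 log units; within the scatter) and this step lies within the scatter, so the assay does not separate the two compounds. For the compounds shown here, the earlier compounds offered no step at this position, and this pair is the first to show that this nitrogen can carry either an open butyl chain or a six-membered aromatic ring of carbon only, with values that cannot be told apart. No measured information on either group bears on this result, and the reason for it remains unknown.

The compounds shown cover only these two groups on this nitrogen, so they leave open whether the same holds for a longer chain, a benzyl group, or a phenyl ring carrying a methoxy group, a carboxylic acid or an amine. They also do not show whether the amide hydrogen matters, since a second butyl group on this nitrogen of the core of compound 1 does not appear among them.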